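The compounds below may be only part of what the source reports. "The series", "measured", "known", "first", "only" and "open" are said of these compounds alone.

Compound 1, `O=C(NO)c1ccc(-c2cn([C@H]3C[C@@H](CO)N(CCCc4ccccc4)C3)nn2)cc1`, in an assay on Sf9 cells for inhibition of histone deacetylase 11 (Homo sapiens), read by fluorescence, tested at 0.5 uM (a higher number here means more inhibition at the concentration tested (going by the name of the read-out), a lower number less inhibition), gives < 10%, a limit of the assay.
Compound 2, `O=C(NO)c1ccc(-c2cn([C@H]3C[C@@H](CO)N(Cc4ccccc4)C3)nn2)cc1`, in this assay gives < 10%, also a limit.
Compound 3, `O=C(/C=C/c1cn([C@@H]2C[C@H](C(=O)O)N(Cc3ccccc3)C2)nn1)NO`, in this assay gives < 10%, again a limit.

Compound 2 stands at the limit, where every value shown sits (the limit of < 10% in this assay, at which 3 of the 3 values shown sit). Going by the values given here, the one measured step, a step that the two limits leave unreadable from compound 1 to compound 2, runs between two limits and cannot be sized. Compound 4, `O=C(NO)c1ccc(-c2cn([C@H]3C[C@H](CO)N(Cc4ccccc4)C3)nn2)cc1`, differs from compound 2 only in configuration: the two compounds have the same atoms and bonds and differ only in configuration as drawn: 1 of 2 stereo elements differ; a stereocentre at a saturated ring carbon is drawn S in compound 2 and R in compound 4. Among the compounds with values here, no measured step concerns a change of configuration, so nothing bears on this move except the position of compound 2 at the limit. Compound 4 is therefore expected to give 5%, between 0% and 15%. The step that the limit leaves unreadable from compound 2 to compound 4 is expected to stay within the scatter.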

Compound 4, a percentage reported as inhibition, at one concentration (the size of the read-out at that concentration, not a potency): 16%
Compound 4: the middle estimate sits 11 percentage points below what was measured; measured number outside the range, above it.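

In this assay compound 4 gives 16%, the first reading among the compounds shown that is a number and not a limit. The change of configuration at the saturated ring carbon gives a number at least 6 percentage points higher from compound 2 to compound 4 (that floor lies within the scatter), so this stereocentre can shift the reading off the limit, though the step is not shown to exceed the scatter. Only configuration separates this pair: the fact that compounds 2 and 4 differ only in the configuration as drawn

The compounds shown leave open whether this configuration would lift the reading with an amine on the chain attached to the ring nitrogen. Also open, going by these compounds, is what the other stereo element, unchanged in this pair, contributes.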